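Benzyl ether on the shared core in this series

A few compounds are considered here, and "the series" means these few. Any claim that something is new, unique, unknown or untested is made for them only; others in the source may bear on it.

Compound 2 `CCO[C@H]1CC[C@H]2CCN(C)[C@H]2C1` carries an ethoxy group on the shared core. In an assay on HEK293 cells for displacement of a labelled ligand from Neuronal acetylcholine receptor; alpha4/beta4 (Rattus norvegicus), with a stated time of 4 h (a lower number here means a stronger inhibitor, a higher number a weaker inhibitor), compound 2 gives only a limit of the assay, > 300000 nM. Compound 1 `CO[C@H]1CC[C@H]2CCN(C)[C@H]2C1` likewise gives only a limit in this assay, > 300000 nM. Both values sit at the limit of > 300000 nM in this assay, at which 2 of the 2 values shown sit, so the step that the two limits leave unreadable from compound 1 to compound 2 cannot be read in either direction. Compound 2 therefore stands at the limit, with no readable step to any other compound.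

Compound 3 `CN1CC[C@@H]2CC[C@H](OCc3ccccc3)C[C@@H]21` differs from compound 2 by phenyl in place of methyl on a saturated chain carbon bound to an oxygen on a saturated carbon. Going by the values given here, no measured step bears on this change: the only step, from compound 1 to compound 2, is unreadable, and nothing else in the set touches the ether substituent. The size of the step in this assay is thus open; the step is estimated as an at least 3.0-fold lower number from compound 2 to compound 3 (0.47 log units; beyond the scatter), with a limit remaining likely. Compound 3 is expected at 100000 nM, within a range from 20000 nM to 300000 nM.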

Compound 3, inhibition constant: 300000 nM
Compound 3: middle estimate off by 3.0-fold (0.48 log units), on the low side; measured number inside the range.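

In this assay compound 3 gives 300000 nM, a measured number rather than a limit, with a number no higher from compound 2 to compound 3 (the limit leaves the size open) and a number no higher from compound 1 to compound 3 (the limit leaves the size open), so the ether carrying phenyl in place of methyl is the only one shown here that yields a number. This is a weak reading, and it shows only that phenyl at this place on the chain carbon bound to the oxygen does not push the number past what the assay can report. The sizes of these steps cannot be read, because compound 1 and compound 2 give only limits: the limit of > 300000 nM in this assay, at which 2 of the 3 values shown sit.

From the compounds shown here alone, whether the phenyl gives any real gain over the methyl or hydrogen of the smaller ethers stays open. Also open, going by these compounds, is whether a longer chain, or an amine or carboxylic acid on the phenyl, would bring the number clearly lower.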